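Replacing cyclohexylmethoxy with phenoxy in an antiproliferative series

The source may report more compounds than this note shows. Statements on the series, on what has been measured and on what is new or still open speak of the compounds shown alone.

Of the compounds shown here, two have been measured in a functional assay on MCF7 cells (Homo sapiens) for antiproliferative activity, read by sulforhodamine B assay, with a stated time of 3 days; a higher number here means a weaker inhibitor, a lower number a stronger inhibitor. Compound 1 `Fc1ccc(Sc2ncnc3[nH]cnc23)cc1` gives 31600 nM, and compound 2 `c1ccc2c(c1)COC(n1cnc3ncnc(OCC4CCCCC4)c31)CO2` gives 13400 nM. Compound 2 therefore holds the lower of the two numbers, and the gap between them lies beyond the usual scatter. The pair differs in more than one place, so it offers no single-change comparison.

Compound 3 `c1ccc(Oc2ncnc3ncn(C4COc5ccccc5CO4)c23)cc1` departs from compound 2 in one place, with phenyl in place of cyclohexylmethyl on an oxygen on an aromatic ring. Within the data shown here, no measured pair isolates this change, so the data give no direct guide to its effect. Among the measured compounds shown here, the only anchors are compound 2 at 13400 nM and compound 1 at 31600 nM, and the new value is expected to stay near them. A small move toward a weaker number is expected, probably not beyond the scatter, and the estimated step is a 1.3-fold higher number from compound 2 to compound 3 (0.13 log units; within the scatter). The estimate for compound 3 in this assay is 18000 nM, with an expected range from 7000 nM to 45000 nM.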

Compound 3, half-maximal inhibitory concentration: 21100 nM
Compound 3: the middle estimate sits 1.2-fold (0.07 log units) below what was measured; measured number inside the range.
By their numbers in this assay, from the lowest: compounds 2, 3 and 1 (each within the scatter of the next, the first and the last beyond it).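

In this assay, among these compounds, the change from cyclohexylmethoxy to phenoxy gives a 1.6-fold higher number from compound 2 to compound 3 (0.20 log units; within the scatter), which provides the first single-change comparison at this position. On the oxygen on an aromatic ring, a six-membered non-aromatic ring of carbon only, carried as cyclohexylmethyl, and a six-membered aromatic ring of carbon only, carried as phenyl, therefore cannot be told apart in this pair. No available measurement accounts for this outcome, and the step alone cannot separate any contribution of ring type from that of the methylene link that leaves with the cyclohexylmethyl group.

Both groups in this pair are made of carbon only, so the compounds shown leave open whether an amine, a carboxylic acid or a longer chain on this oxygen would move the number beyond the scatter. Among the compounds shown here, they also leave open whether the exchange of cyclohexylmethoxy for phenoxy would read the same way on a core other than the one shared by compound 2 and compound 3.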